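This account rests on a few compounds, and the source may have more. Where it says the series, first, only, none or still open, it means among the compounds named here.

Notes on the series, all read in an ADME assay on THP-1 cells (Homo sapiens) for cytotoxicity, read by flow cytometry and propidium iodide staining, with a stated time of 72 h; on this read-out higher numbers stand for weaker inhibition and lower numbers for stronger inhibition. Compound 1 `CC(=O)Nc1ccc(O)c(C(=O)/C=C/c2cccc(F)c2)c1` gives 78600 nM. Compound 2 `CC(=O)Nc1ccc2oc(-c3ccccc3)cc(=O)c2c1` gives 97000 nM. Compound 3 `CC(=O)Nc1ccc2oc(-c3ccccc3)c(O)c(=O)c2c1` gives 36000 nM, the lowest of the three numbers, with the other two standing higher by margins beyond the scatter.

Compound 4 `CC(=O)Nc1ccc2oc(-c3ccccc3F)c(O)c(=O)c2c1` keeps everything in compound 3 except one place: fluoro in place of hydrogen on an aromatic carbon. In words, this is fluoro in place of hydrogen on an aromatic carbon, the phenyl becoming 2-fluorophenyl.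

Among the measured compounds shown here, no measured step covers this change. For the measured compounds named here, the only one-place step available is a 2.7-fold lower number from compound 2 to compound 3 (0.43 log units; beyond the scatter), a modest move that comes from hydroxy in place of hydrogen, so it bears only indirectly, as a guide to how far one small substitution has shifted this read-out. Going by the values given here, compound 1 also carries a fluoro, but on a different core, and no one-place step links it to the others.

On that thin basis, a small change with no firm direction is expected, and the estimated 1.1-fold lower number from compound 3 to compound 4 (0.05 log units; within the scatter) is not expected to exceed the scatter in this assay. The estimate for compound 4 is 32000 nM, with an expected range from 15000 nM to 70000 nM.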

Compound 4, half-maximal inhibitory concentration: 47000 nM
Beside the measured number, compound 4's estimate is 1.5-fold (0.17 log units) below it; measured number inside the range.
By their numbers in this assay, from the lowest: compounds 3, 4, 1 and 2 (each within the scatter of the next, the first and the last beyond it).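

Fluoro in place of hydrogen on an aromatic carbon, ortho to a large group, is the first change on the phenyl of the shared core to be read in this assay, and the step is a 1.3-fold higher number from compound 3 to compound 4 (0.12 log units; within the scatter). So phenyl to 2-fluorophenyl does not separate compound 4 from compound 3 on this read-out, whereas the hydroxy change on the shared core, a 2.7-fold lower number from compound 2 to compound 3 (0.43 log units; beyond the scatter), lies beyond the scatter, and this single fluoro does not carry the series past what that hydroxy step showed. Nothing available here explains this result.

Still open, from the compounds shown here alone, is whether a larger or differently built group on that same aromatic carbon, such as chloro, methoxy, trifluoromethyl or an amine, would move the number beyond the scatter from compound 3, since one fluoro at one place gives no direction for the ring as a whole. Also open, going by these compounds, is whether 2-fluorophenyl would read the same on the core of compound 2, which lacks the hydroxy, so the two changes cannot yet be judged together.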